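Trifluoromethyl for trifluoromethoxy: notes on the solubility step

The compounds below may be only part of what the source reports. "The series", "measured", "known", "first", "only" and "open" are said of these compounds alone.

Measured in a physicochemical assay for solubility, read by HPLC, measured as kinetic solubility, with a stated time of 15 min; on this read-out lower numbers stand for lower solubility and higher numbers for higher solubility:
- compound 1 `O=[N+]([O-])c1cn2c(n1)OC[C@H](OCc1ccc(-c3ccc(OC(F)(F)F)cc3Cl)cc1)C2`: < 0.1 ug/mL (a limit)
- compound 2 `O=[N+]([O-])c1cn2c(n1)OC[C@H](OCc1ccc(-c3ccc(C(F)(F)F)cc3Cl)cn1)C2`: 1 ug/mL

Compound 1 has no numerical reading, only a limit of the assay, < 0.1 ug/mL. Its true position is therefore unknown, and any comparison from it has an open end. For the measured compounds named here, compound 2 gives a number, 1 ug/mL, and this is the only number available so far.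

Compound 3 `O=[N+]([O-])c1cn2c(n1)OC[C@H](OCc1ccc(-c3ccc(C(F)(F)F)cc3Cl)cc1)C2` follows from compound 1 by one change: trifluoromethyl in place of trifluoromethoxy on an aromatic carbon, meta to a chloro group and para to a large group (trifluoromethyl in place of trifluoromethoxy on an aromatic carbon). Going by the values given here, no measured pair isolates this change, so its size in this assay cannot be read from the data. The step of an at least 2.0-fold higher number from compound 1 to compound 3 (0.30 log units; that floor lies within the scatter) is expected to be small and upward, close to the scatter. The reading for compound 2, 1 ug/mL, is taken as the approximate top of the range considered. A result reported only as a limit remains possible. In this assay the expected value for compound 3 is 0.2 ug/mL, with an estimated range from 0.1 ug/mL to 0.8 ug/mL.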

Compound 3, solubility: < 0.1 ug/mL
Compound 3: no number, only a limit; the forecaster's own chance of this, stated with the estimate: 35%; at least 2.0-fold (0.30 log units) between middle value and limit.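

Compound 1 and compound 3 each give only a limit in this assay, so no step between them can be read, the reason being this: the limit of < 0.1 ug/mL in this assay, at which 2 of the 3 values shown sit.

The compounds shown leave open how large the effect of trifluoromethyl in place of trifluoromethoxy on an aromatic carbon is, and where compound 1 and compound 3 truly stand relative to each other.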